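The source may report more compounds than this note shows. Statements on the series, on what has been measured and on what is new or still open speak of the compounds shown alone.

Measured compounds:
compound 1 `O=C(CC[C@H](NC(=O)c1cc2ccccc2cn1)C(=O)OCc1ccccc1)OCc1ccccc1` gives 25.2% in a functional assay on the whole organism (CCRF S-180 cells, Mus musculus) for inhibition, in a xenograft, with stated times of 7 days and 24 h, at a dose of 100 umol/kg by the intraperitoneal route; on this read-out lower numbers stand for less inhibition and higher numbers for more inhibition at the one dose given (going by the name of the read-out)
compound 2 `NC(=O)C[C@H](NC(=O)c1cc2ccccc2cn1)C(=O)OCc1ccccc1` gives 36.7%
compound 3 `O=C(CNC(=O)c1cc2ccccc2cn1)OCc1ccccc1` gives 16.1%

Compound 3 stands lowest of the three numbers. Its nearest neighbour is compound 1, with a number 9.1 percentage points lower from compound 1 to compound 3 (within the scatter), a gap within the scatter, so no order between compound 3 and compound 1 can be claimed. Compound 2 stands furthest, with a number 20.6 percentage points lower from compound 2 to compound 3 (beyond the scatter), a modest step beyond the scatter.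

Compound 4 `CC[C@@H](C)[C@H](NC(=O)c1cc2ccccc2cn1)C(=O)OCc1ccccc1` is not yet measured. The change from compound 3 is sec-butyl in place of hydrogen on a saturated chain carbon bound to an amide-type nitrogen and a carbonyl carbon.

Among the measured compounds shown here, two measured steps bear on this place, both recorded as removal of a group from that saturated chain carbon: a number 9.1 percentage points lower from compound 1 to compound 3 (within the scatter), within the scatter, and a number 20.6 percentage points lower from compound 2 to compound 3 (beyond the scatter), modest and beyond the scatter. Both removals gave lower numbers, so putting a group back at that carbon may raise the number. Neither group that was removed resembles sec-butyl, so the size of the step is uncertain; a small rise, possibly within the scatter, is expected.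

For compound 4 the expected value is 25%, within 8% to 42%, which would mean an expected step of a number 8.9 percentage points higher from compound 3 to compound 4 (within the scatter).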

Compound 4, a percentage reported as inhibition, in the whole organism at one dose (the size of the read-out at that dose, not a potency): 20.9%
Beside the measured number, compound 4's estimate is 4.1 percentage points above it, within the range that was stated.
By their numbers in this assay, from the lowest: compounds 3, 4 and 1 (each within the scatter of the next); then compound 2.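

In this assay, sec-butyl on the saturated chain carbon bound to an amide-type nitrogen and a carbonyl carbon cannot be told apart from hydrogen (a number 4.8 percentage points higher from compound 3 to compound 4 (within the scatter)) or from 2-(benzyloxycarbonyl)ethyl (a number 4.3 percentage points lower from compound 1 to compound 4 (within the scatter)). Compounds 1, 3 and 4 therefore show no order among themselves, and filling this carbon with a group does not by itself move the number beyond the scatter. Carbamoylmethyl is the only group shown here that stands clear of sec-butyl (a number 15.8 percentage points lower from compound 2 to compound 4 (beyond the scatter)), and compound 2 alone separates from the rest.

From the compounds shown here alone, it remains open whether an amine, a carboxylic acid or a longer chain ending in carbamoyl at this carbon would stand with compound 2 or with the other three. Nothing measured here accounts for the separation of compound 2.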